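The source may hold more compounds than are shown below. What is called first, only, known or untested is meant among the compounds shown, and "the series" means these compounds.

Compound 1 `CC(C)(C)c1ccc(NC(=O)c2csc(Cc3c(Cl)cccc3Cl)n2)cc1`: 300 nM
Compound 2 `CN(C)c1ccc(NC(=O)c2csc(Cc3c(Cl)cccc3Cl)n2)cc1`: 1270 nM
Compound 3 `COc1ccc(NC(=O)c2csc(Cc3c(Cl)cccc3Cl)n2)cc1`: > 4000 nM

The three measured compounds share one core and differ only in the group on the ring that sits on an amide-type nitrogen. In an assay on CHO cells, read by calcium flux (a higher number here means a weaker inhibitor, a lower number a stronger inhibitor), compound 1 gives 300 nM and compound 2 gives 1270 nM. For compound 3 this assay reports only a limit, > 4000 nM, not a number. The steps run a 4.2-fold higher number from compound 1 to compound 2 (0.63 log units; beyond the scatter), an at least 13-fold higher number from compound 1 to compound 3 (1.12 log units; beyond the scatter) and an at least 3.1-fold higher number from compound 2 to compound 3 (0.49 log units; beyond the scatter), so compound 3 stands as the weakest of the three.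

Compound 4 `O=C(Nc1cccc(Br)c1)c1csc(Cc2c(Cl)cccc2Cl)n1` is not yet measured. (3-bromophenyl in place of 4-methoxyphenyl on an amide-type nitrogen). For the measured compounds named here, no measured step swaps this whole ring, but the three steps above show that changes on it shift the number by modest to large amounts. Compound 4 is therefore expected to fall back inside the measurable range, with an at least 2.6-fold lower number from compound 3 to compound 4 (0.42 log units; beyond the scatter) as the estimated step. The estimate for compound 4 is 1500 nM, expected between 400 nM and 6000 nM.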

Compound 4, half-maximal inhibitory concentration: > 4000 nM
Compound 4 was reported as a limit (the forecaster's own chance of this, stated with the estimate: 30%); middle value at least 2.6-fold (0.42 log units) from the limit.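

For the compounds shown here, compound 3 and compound 4 are each reported in this assay only as a limit, so no step between them can be read: the limit of > 4000 nM in this assay, at which 2 of the 4 values shown sit. The compounds shown leave open how strong either compound really is, and whether 3-bromophenyl and 4-methoxyphenyl differ at all.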